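Tert-butyl for 1-methylcyclopropyl: a cytotoxicity check

The source may report more compounds than this note shows. Statements on the series, on what has been measured and on what is new or still open speak of the compounds shown alone.

Measured so far:
compound 1 `N#CCCCn1c(Cn2c(=O)n(-c3ccncn3)c3ccncc32)cc2cc(Cl)ccc21`: > 50000 nM
compound 2 `CC1(n2c(=O)n(Cc3cc4cc(Cl)ccc4n3CCCS(C)(=O)=O)c3cnccc32)CC1`: > 50000 nM
compound 3 `O=c1n(Cc2nc3ncccc3n2CCCCO)c2cnccc2n1C1CC1`: > 100000 nM

Three compounds have been run in an ADME assay on HeLa cells (Homo sapiens) for cytotoxicity, read by ATP content, with a stated time of 3 days; a lower number here means that less compound is tolerated, a higher number that more compound is tolerated. For compound 1 the result is a limit of the assay, > 50000 nM. For compound 2 the result is likewise a limit, > 50000 nM. For compound 3 the result is again a limit, > 100000 nM. Two of the three values sit at the limit of > 50000 nM in this assay, at which 2 of the 3 values shown sit. One sits at the limit of > 100000 nM in this assay, at which 1 of the 3 values shown sits. For the measured compounds named here, compound 2 thus stands among the compounds for which no number, only a limit, is known in this assay, and no step between measured compounds can be drawn from these values.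

Compound 4 `CC(C)(C)n1c(=O)n(Cc2cc3cc(Cl)ccc3n2CCCS(C)(=O)=O)c2cnccc21` differs from compound 2 in one place: tert-butyl in place of 1-methylcyclopropyl on an aromatic nitrogen. Going by the values given here, with every value so far a limit, no step beyond the scatter is expected in this assay in either direction. Compound 4 is expected to give 60000 nM, with a range from 30000 nM to 120000 nM. The expected step is a step that the limit leaves unreadable from compound 2 to compound 4, most likely ending again at a limit rather than a number.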

Compound 4, half-maximal cytotoxic concentration: > 50000 nM
Compound 4 gave a limit, no number (the forecaster's own chance of this, stated with the estimate: 80%); the middle value is on the limit's open side.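

Compound 2 and compound 4 each gave only a limit, not a number, so no step can be read between them. The compounds shown leave open whether tert-butyl in place of 1-methylcyclopropyl on an aromatic nitrogen changes the result in this assay at all.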